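A few compounds are considered here, and "the series" means these few. Any claim that something is new, unique, unknown or untested is made for them only; others in the source may bear on it.

Compound 1 `COc1cc2ncnc(Nc3ccc(B(O)O)cc3)c2cc1OC`: > 1000 nM
Compound 2 `COCCOc1cc2ncnc(Nc3cccc(B(O)O)c3)c2cc1OC`: > 1000 nM

In an assay on isolated protein for inhibition of vascular endothelial growth factor receptor 1 (Homo sapiens), read by ELISA, with a stated time of 20 min (on this read-out lower numbers stand for stronger inhibition and higher numbers for weaker inhibition), compound 1 gives > 1000 nM, which is a limit of the assay rather than a number. Compound 2 records > 1000 nM in this assay, a limit as well. Both values sit at the same limit (the limit of > 1000 nM in this assay, at which 2 of the 2 values shown sit), so compound 2 stands together with compound 1 and nothing separates the two on the numbers shown.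

Compound 3 `COCCOc1cc2ncnc(Nc3ccc(B(O)O)cc3)c2cc1OC` differs from compound 2 by a group of 9 heavy atoms (6 carbon, 1 boron, 2 oxygen; one six-membered aromatic ring of carbon only) in place of a group of 9 heavy atoms (6 carbon, 1 boron, 2 oxygen; one six-membered aromatic ring of carbon only), on a nitrogen on an aromatic ring.

Compound 1, which already carries the group that enters, gives > 1000 nM in this assay, a limit. For the measured compounds named here, no step between measured compounds is available, so the change from compound 2 to compound 3 is expected to bring no shift beyond the scatter, a step that the limit leaves unreadable from compound 2 to compound 3. Compound 3 is therefore estimated at 3000 nM, within 1000 nM to 10000 nM, and most likely reported again as a limit.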

Compound 3, half-maximal inhibitory concentration: > 1000 nM
Compound 3: a limit, no number (the forecaster's own chance of this, stated with the estimate: 85%); the middle value does not contradict the limit.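

Compound 3 gives > 1000 nM which is again a limit of the assay and not a number, so its steps from compound 1 and from compound 2 cannot be read: the limit of > 1000 nM in this assay, at which 3 of the 3 values shown sit. Going by these compounds, how strongly compound 1, compound 2 and compound 3 actually inhibit in this assay stays open, and so does whether either change matters.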